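The source may report more compounds than this note shows. Statements on the series, on what has been measured and on what is new or still open speak of the compounds shown alone.

In a functional assay on HT-29 cells (Homo sapiens) for cytotoxicity, read by MTT assay, with a stated time of 6 days (a lower number here means that less compound is needed, a higher number that more compound is needed for the effect), compound 1 `COC(=O)c1c(-c2ccc([N+](=O)[O-])cc2)oc2ccccc2c1=O` gives > 25 ug/mL, a limit and not a number. Compound 2 `COC(=O)c1c(-c2ccc([N+](=O)[O-])cc2)oc2cc(OC)ccc2c1=O` gives > 25 ug/mL, also only a limit. Compound 1 thus stands at the limit of > 25 ug/mL in this assay, at which 2 of the 3 values shown sit, without an exact value. For the measured compounds named here, the one measured step, a step that the two limits leave unreadable from compound 1 to compound 2, offers no size to carry forward. Compound 3 `COC(=O)c1c(-c2ccc(OCc3ccccc3)cc2)oc2ccc(OC)cc2c1=O`, which has no nitro group, gives a true number, 15.6 ug/mL, but differs from compound 1 in more than one place. Compound 4 `COC(=O)c1c(-c2ccc(O)cc2)oc2ccccc2c1=O` changes a single group of compound 1: hydroxy in place of nitro on an aromatic carbon. Going by the values given here, with compound 3 as the only guide, a modest move toward less compound needed is expected, and a limit may again be reported. The expected change is an at least 1.2-fold lower number from compound 1 to compound 4 (0.09 log units; that floor lies within the scatter), though it remains uncertain. Compound 4 is estimated at 20 ug/mL, within an expected range from 8 ug/mL to 40 ug/mL.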

Compound 4, concentration for half-maximal effect: > 25 ug/mL
Compound 4 gave a limit, no number; the forecaster's own chance of this, stated with the estimate: 45%; at least 1.2-fold (0.09 log units) between middle value and limit.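

Compound 1 and compound 4 both end at a limit and not at a number, so no step can be read between them: the limit of > 25 ug/mL in this assay, at which 3 of the 4 values shown sit.

Going by these compounds, whether hydroxy in place of nitro changes the amount of compound needed, and by how much, stays open.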